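The compounds below may be only part of what the source reports. "The series", "measured", "known", "first", "only" and "open" are said of these compounds alone.

Compound 2 `O=C(O)CC[C@H]1CCc2cc(-c3cc(OC(F)(F)F)ccc3F)ccc2O1` carries a 2-carboxyethyl group on a saturated ring carbon of its core. Within the data shown here, in a functional assay on HEK293 cells for agonist activity at Free fatty acid receptor 1 (Homo sapiens), read by HTRF and inositol phosphate accumulation, with a stated time of 60 min (a higher number here means that more compound is needed for the effect, a lower number that less compound is needed), compound 2 gives 2100 nM, the only finite number in the set. Compound 1 `O=C(O)[C@H]1C[C@@H]1[C@H]1CCc2cc(-c3cc(OC(F)(F)F)ccc3F)ccc2O1` bears a 2-carboxycyclopropyl group in the same place; in this assay compound 1 reaches only the limit of > 10000 nM, so its number is not known. Among the measured compounds shown here, that pair supplies the one measured step: an at least 4.7-fold lower number from compound 1 to compound 2 (0.67 log units; beyond the scatter), a comparison that rests on (the limit of > 10000 nM in this assay, at which 1 of the 2 values shown sits).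

Compound 3 `O=C(O)[C@@H]1C[C@H]1[C@H]1CCc2cc(-c3cc(OC(F)(F)F)ccc3F)ccc2O1` is the compound now to be measured. Its change from compound 2 is 2-carboxycyclopropyl in place of 2-carboxyethyl on a saturated ring carbon. It is the reverse of the measured step in kind, yet compound 3 differs from compound 1 in the arrangement of the two defined stereocentres of the cyclopropane, so the measured step does not transfer directly. A weakening beyond the scatter is nonetheless expected, with a sizeable chance that this assay again returns only a limit. The expected step is a 1.9-fold higher number from compound 2 to compound 3 (0.28 log units; within the scatter). Compound 3 is estimated at 4000 nM, in a range from 1000 nM to 16000 nM.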

Compound 3, half-maximal effective concentration: > 10000 nM
Compound 3: a limit, no number; the forecaster's own chance of this, stated with the estimate: 40%; at least 2.5-fold (0.39 log units) between middle value and limit.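

In this assay, the one readable new step is an at least 4.7-fold higher number from compound 2 to compound 3 (0.67 log units; beyond the scatter), so the 2-carboxycyclopropyl group on this saturated ring carbon now falls short of the 2-carboxyethyl group in a second stereochemical form, though the size of that step remains a lower bound: the limit of > 10000 nM in this assay, at which 2 of the 3 values shown sit.
Compound 3 gives only a limit, > 10000 nM, and not a number.
The step between compound 1 and compound 3 cannot be read, and what this pair adds is that changing the configuration at the two cyclopropane stereocentres does not bring a finite value into view: the fact that compounds 1 and 3 differ only in the configuration as drawn

The compounds shown do not tell how far compound 1 and compound 3 lie beyond the limit, or whether either form of the cyclopropane differs from the other at all. They also leave open what the other configuration at the saturated ring carbon would give, and whether a 3-carboxypropyl chain or a tetrazole in this place would give a lower number in this assay than compound 2 does.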